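The source may report more compounds than this note shows. Statements on the series, on what has been measured and on what is new or still open speak of the compounds shown alone.

In an ADME assay on MDBK cells (Bos taurus) for cytotoxicity, read by MTT assay, with a stated time of 96 h (on this read-out lower numbers stand for higher toxicity in this test and higher numbers for lower toxicity in this test), compound 1 `CC(=O)c1ccc2[nH]c(-c3ccc(Cl)cc3)nc2c1` gives only a limit, > 100000 nM. Compound 2 `CC(=O)c1ccc2c(c1)nc(-c1ccc(Cl)cc1)n2C1CCCCC1` likewise reaches only a limit there, > 100000 nM. The step that the two limits leave unreadable from compound 2 to compound 1 therefore cannot be read; the change made is hydrogen in place of cyclohexyl on an aromatic nitrogen. Compound 3 `C/C(=N\NC(N)=O)c1ccc2c(c1)nc(-c1ccoc1)n2C1CCCCC1` also gives only a limit in this assay, > 100000 nM. How the core of compound 3 differs from that of compound 2 is not broken down here. Compound 4 `C/C(=N\NC(N)=O)c1ccc2[nH]c(-c3ccoc3)nc2c1` is still to be measured; it differs from compound 3 by hydrogen in place of cyclohexyl on an aromatic nitrogen, the same kind of change as that from compound 2 to compound 1, though here the ring atom next to the changed nitrogen bears a furan-3-yl group rather than a 4-chlorophenyl group. Because every value shown sits at the limit of > 100000 nM in this assay, at which 3 of the 3 values shown sit, compound 4 is expected to return a limit too, with an estimated step that the limit leaves unreadable from compound 3 to compound 4 that is essentially flat. Compound 4 is thus estimated at 150000 nM, within 50000 nM to 500000 nM.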

Compound 4, half-maximal cytotoxic concentration: > 100000 nM
Compound 4: only a limit was reported; the forecaster's own chance of this, stated with the estimate: 85%; the middle value does not contradict the limit.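

The step between compound 3 and compound 4 cannot be read, since both give only limits in this assay: the limit of > 100000 nM in this assay, at which 4 of the 4 values shown sit. The compounds shown leave open whether hydrogen in place of cyclohexyl changes the half-maximal cytotoxic concentration at all.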